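The source may report more compounds than this note shows. Statements on the series, on what has been measured and on what is new or still open speak of the compounds shown alone.

Compounds measured in an ADME assay on HOS cells (Homo sapiens) for cytotoxicity; on this read-out higher numbers stand for lower toxicity in this test and lower numbers for higher toxicity in this test; each value is a limit of the assay and not a number:

Compound 1 `CN(Cc1nc2cccc(C(=O)NCCCN)c2[nH]1)C1CCCc2cccnc21`: > 20000 nM
Compound 2 `CN(Cc1nc2cccc(CN)c2[nH]1)C1CCCc2cccnc21`: > 20000 nM
Compound 3 `CN(Cc1nc2cccc(CNCCN)c2[nH]1)C1CCCc2cccnc21`: > 20000 nM

Compound 3 therefore has no exact position on this scale, and it shares its standing with the other two: the limit of > 20000 nM in this assay, at which 3 of the 3 values shown sit. Compound 4 `CN(Cc1nc2cccc(CCCN)c2[nH]1)C1CCCc2cccnc21` carries 2-aminoethyl in place of (2-aminoethyl)amino on a saturated chain carbon bound to an aromatic carbon.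

Going by the values given here, three measured steps bear on this change: a step that the two limits leave unreadable from compound 1 to compound 2, a step that the two limits leave unreadable from compound 1 to compound 3 and a step that the two limits leave unreadable from compound 2 to compound 3. None of them has a readable size. Compound 1, compound 2 and compound 3 differ in this same side chain, yet all remain at the limit in this assay. No step beyond the usual scatter is therefore expected in either direction, and the expected step is a step that the limit leaves unreadable from compound 3 to compound 4. A further limit is the likeliest report. For compound 4 the estimated value is 22000 nM, within an expected range of 10000 nM to 45000 nM.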

Compound 4, half-maximal cytotoxic concentration: 10000 nM
Compound 4: the middle estimate sits 2.2-fold (0.34 log units) above what was measured; low and high end bracket the measured number.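

In this assay compound 4 is the only compound shown with a number instead of a limit, and the steps among the three earlier compounds cannot be read: the limit of > 20000 nM in this assay, at which 3 of the 4 values shown sit.

Going by these compounds alone, with 3-aminopropyl on the aromatic carbon, the series gains its only readable steps, namely an at least 2.0-fold lower number from compound 3 to compound 4 (0.30 log units; that floor lies within the scatter), an at least 2.0-fold lower number from compound 2 to compound 4 (0.30 log units; that floor lies within the scatter) and an at least 2.0-fold lower number from compound 1 to compound 4 (0.30 log units; that floor lies within the scatter). Going by these compounds, each is only a floor within the scatter: a real change is not established, and the true size of these steps remains unknown.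

On these data alone, it remains open how the number in this assay would respond to a longer chain at this place. As far as these compounds go, it is equally open what a tertiary amine or a carboxylic acid at the chain end would do.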